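Ethylsulfanyl in Place of Benzyloxy on a Purine Riboside

A few compounds are considered here, and "the series" means these few. Any claim that something is new, unique, unknown or untested is made for them only; others in the source may bear on it.

Of the compounds shown here, two have been measured in an assay on isolated protein for binding affinity to Equilibrative nucleoside transporter 1 (Homo sapiens); a higher number here means a weaker inhibitor, a lower number a stronger inhibitor. Compound 1, `Nc1ncnc2c1ncn2[C@@H]1O[C@H](COCCOCCNc2ncnc3c2ncn3[C@@H]2O[C@H](CO)[C@@H](O)[C@H]2O)[C@@H](O)[C@H]1O`, gives 912000 nM in this assay. Compound 2, `OC[C@H]1O[C@@H](n2cnc3c(OCc4ccccc4)ncnc32)[C@H](O)[C@@H]1O`, gives 2090 nM in this assay, the lower of the two numbers and by a margin that lies well beyond the usual scatter; compound 1 is the only other point, so no gradual trend can be drawn from this pair.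

Compound 3, `CCSc1ncnc2c1ncn2[C@@H]1O[C@H](CO)[C@@H](O)[C@H]1O`, is the next candidate. It differs from compound 2 in a single place: ethylsulfanyl in place of benzyloxy on an aromatic carbon. Going by the values given here, nothing measured so far bears on how a small sulfur-linked chain fares in comparison with the benzyloxy group at this position, so the expectation for compound 3 rests on the value of compound 2 alone and on the loss of the aromatic ring that the change entails.

Compound 3 is expected to give a higher number than compound 2, a step of a 3.8-fold higher number from compound 2 to compound 3 (0.58 log units; beyond the scatter) in this assay. The estimate for compound 3 in this assay is 8000 nM, with a range from 1500 nM to 40000 nM.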

Compound 3, half-maximal inhibitory concentration: 57500 nM
The estimate for compound 3 lay 7.2-fold (0.86 log units) below the measured number, outside the stated range (above it).
By their numbers in this assay, from the lowest: compound 2; then compound 3; then compound 1.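

In this assay the change appears as a 28-fold higher number from compound 2 to compound 3 (1.44 log units; beyond the scatter), a large step beyond the scatter, so this aromatic carbon is not indifferent to the group it carries. With the sugar and the rest of the core unchanged, replacing benzyloxy, with its six-membered aromatic ring of carbon only, by ethylsulfanyl, with no ring, is enough to weaken the compound this far. This single change removes the ring, shrinks the group and exchanges the linking oxygen for sulfur, and no independent information is available to explain the step or divide it among these differences.

The compounds shown leave open whether the ring or the linking atom accounts for most of the step: benzylsulfanyl would keep the ring on sulfur, while ethoxy would keep the small chain on oxygen. A longer chain on sulfur or an amine on the same aromatic carbon would show further how the number follows the group at this position.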